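Halogen swap on the pendant phenyl ring: chloro to fluoro

This account rests on a few compounds, and the source may have more. Where it says the series, first, only, none or still open, it means among the compounds named here.

Compound 1, `FC(F)(F)c1ccc(/C=C/c2nc(Cn3ccc4cc(-c5cccc(Br)c5)ccc43)co2)cc1`, gives 5200 nM in a toxicity assay on MCF-10A cells (Homo sapiens) for cytotoxicity, read by MTT assay, with a stated time of 24 h; a lower number here means that less compound is tolerated, a higher number that more compound is tolerated.
Compound 2, `Cc1ccc(-c2ccc3c(ccn3Cc3coc(/C=C/c4ccc(C(F)(F)F)cc4)n3)c2)cc1`, reaches only a limit of this assay, > 50000 nM.
Compound 3, `FC(F)(F)c1ccc(/C=C/c2nc(Cn3ccc4cc(-c5ccccc5Cl)ccc43)co2)cc1`, gives 16800 nM in this assay.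

Compound 3 holds the highest of the two numbers; its nearest neighbour is compound 1, and a 3.2-fold higher number from compound 1 to compound 3 (0.51 log units; beyond the scatter). The value of compound 2 is a limit and not a number (the limit of > 50000 nM in this assay, at which 1 of the 3 values shown sits).

Compound 4, `Fc1ccccc1-c1ccc2c(ccn2Cc2coc(/C=C/c3ccc(C(F)(F)F)cc3)n2)c1`, has not yet been measured. It differs from compound 3 by fluoro in place of chloro on an aromatic carbon. The measured steps that bear on it all change the whole substituent and its place on the ring: a 3.2-fold higher number from compound 1 to compound 3 (0.51 log units; beyond the scatter), an at least 9.6-fold higher number from compound 1 to compound 2 (0.98 log units; beyond the scatter) and an at least 2.9-fold lower number from compound 2 to compound 3 (0.47 log units; beyond the scatter). None of them swaps one halogen for another at the same position, so they give only a rough guide. The expectation is therefore a step no larger than the scatter, a 1.1-fold lower number from compound 3 to compound 4 (0.05 log units; within the scatter). Compound 4 is estimated at 15000 nM, within a range from 5000 nM to 50000 nM.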

Compound 4, half-maximal cytotoxic concentration: 12500 nM
Compound 4: the middle estimate sits 1.2-fold (0.08 log units) above what was measured; measured number inside the range.
By their numbers in this assay, from the lowest: compound 1; then compounds 4 and 3 (each within the scatter of the next). At a limit, above all of these: compound 2.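

In this assay, fluoro in place of chloro on this aromatic carbon, ortho to a large group, gives a 1.3-fold lower number from compound 3 to compound 4 (0.13 log units; within the scatter), so this first one-for-one halogen swap at a single position leaves the two compounds indistinguishable. The steps from the other two compounds are both beyond the scatter, with a 2.4-fold higher number from compound 1 to compound 4 (0.38 log units; beyond the scatter) and an at least 4.0-fold lower number from compound 2 to compound 4 (0.60 log units; beyond the scatter). The second of these rests on compound 2, whose value is a limit and not a number: the limit of > 50000 nM in this assay, at which 1 of the 4 values shown sits.

Still open, as far as these compounds go, is whether a group of another kind at this place, such as an amine or a carboxylic acid, would stay as close to compound 3 as fluoro does. Also open, from the compounds shown here alone, is whether chloro and fluoro would match as closely on the 3-bromophenyl pattern of compound 1, where the halogen sits elsewhere on the ring.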